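Arylthio for sec-butyl on a benzoylguanidine sulfone

A few compounds are considered here, and "the series" means these few. Any claim that something is new, unique, unknown or untested is made for them only; others in the source may bear on it.

Compound 2, `CCC(C)c1cc(C)c(C(=O)N=C(N)N)cc1S(C)(=O)=O`: 8 nM
Compound 1, `CCN(CC)Cc1cc(Br)c(S(C)(=O)=O)cc1C(=O)N=C(N)N`: 9500 nM

In a functional assay for inhibition of sodium/hydrogen exchanger (Oryctolagus cuniculus) (a lower number here means a stronger inhibitor, a higher number a weaker inhibitor), compound 2 gives 8 nM, the lower of the two numbers here. In this assay compound 1 gives 9500 nM, a gap far beyond the scatter. Compound 3, `Cc1cc(Sc2cccc(Cl)c2)c(S(C)(=O)=O)cc1C(=O)N=C(N)N`, is not yet measured. It differs from compound 2 in one place: (3-chlorophenyl)sulfanyl in place of sec-butyl on an aromatic carbon. Among the compounds with values here, with no measured pair of this kind to lean on, a small weakening is expected, a 2.5-fold higher number from compound 2 to compound 3 (0.40 log units; beyond the scatter), which may well stay within the scatter. Compound 3 is therefore expected to give 20 nM, between 5 nM and 100 nM.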

Compound 3, half-maximal inhibitory concentration: 37 nM
The estimate for compound 3 lay 1.9-fold (0.27 log units) below the measured number; the measured number falls inside the stated range.
By their numbers in this assay, from the lowest: compound 2; then compound 3; then compound 1.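

In this assay, putting (3-chlorophenyl)sulfanyl in place of sec-butyl, ortho to the methylsulfonyl group, gives a 4.6-fold higher number from compound 2 to compound 3 (0.67 log units; beyond the scatter). The step is modest: this position accepts a group carrying an aromatic ring, and compound 3 still gives 37 nM. No separate measurement bears on what sets the size of this step.

The compounds shown leave open what a plain phenylsulfanyl group without the chlorine would give at this position. They also leave open how a phenoxy group, with oxygen in place of sulfur, or a piperidine would compare there.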